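The source may report more compounds than this note shows. Statements on the series, on what has been measured and on what is new or still open speak of the compounds shown alone.

Series in an ADME assay on MT2 cells (Homo sapiens) for cytotoxicity, read by XTT assay, with a stated time of 4 days; a higher number here means that more compound is tolerated, a lower number that less compound is tolerated:
- compound 1 `Cc1nc(C(NC(=O)C(=O)Nc2ccc(Cl)cc2)C2CCNCC2)sc1CO`: > 81000 nM, a limit
- compound 2 `Cc1ccc(NC(=O)C(=O)NC(c2nc(C)c(CCO)s2)C2CCCCN2)cc1F`: 85000 nM
- compound 3 `Cc1nc(C(NC(=O)C(=O)Nc2ccc(Cl)cc2)C2CCNCC2)sc1CCO`: > 78500 nM, a limit

Compound 1 has no number, only the limit > 81000 nM. Compound 3 also has only a limit, > 78500 nM. For the measured compounds named here, compound 2 gives the only true number, 85000 nM, and it differs from compound 1 in more than one place.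

Compound 4 `Cc1nc(C(NC(=O)C(=O)Nc2ccc(Cl)cc2)C2CCCNC2)sc1CO` carries piperidin-3-yl in place of piperidin-4-yl on a saturated chain carbon bound to an amide-type nitrogen and an aromatic carbon. The two have the same atoms, joined differently.

Going by the values given here, the one measured step, a step that the two limits leave unreadable from compound 1 to compound 3, lies at another place in the molecule and gives no size to carry over. Among the compounds with values here, no measured step covers this change directly. Within the data shown here, with compound 2 at 85000 nM as the only number to lean on, no shift beyond the scatter is expected in this assay, in either direction. The expected outcome is an at least 1.0-fold lower number from compound 1 to compound 4 (0.00 log units; that floor lies within the scatter). A report of only a limit is also likely.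

Compound 4 is estimated at 80000 nM, with an expected range of 35000 nM to 130000 nM.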

Compound 4, half-maximal cytotoxic concentration: > 81000 nM
Compound 4 was reported as a limit; the forecaster's own chance of this, stated with the estimate: 65%; at least 1.0-fold (0.00 log units) between middle value and limit.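

Compound 1 and compound 4 are both reported only as limits, and no step can be read between them for piperidin-3-yl in place of piperidin-4-yl. The compounds shown leave open whether this change moves the half-maximal cytotoxic concentration at all, in either direction.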